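This account rests on a few compounds, and the source may have more. Where it says the series, first, only, none or still open, it means among the compounds named here.

Of the compounds shown here, three with a shared core have been measured in an ADME assay on HS27 cells (Homo sapiens) for cytotoxicity, read by MTT assay; a lower number here means a stronger inhibitor, a higher number a weaker inhibitor. Compound 1 `O=C(Nc1ccc(-n2ccc3nc(C(=O)NCc4ccccc4)ccc32)cc1)Nc1ccc(Cl)c(C(F)(F)F)c1` gives 3000 nM. Compound 2 `COC(=O)c1ccc2c(ccn2-c2ccc(NC(=O)Nc3ccc(Cl)c(C(F)(F)F)c3)cc2)n1` gives 8200 nM. Compound 3 `NC(=O)c1ccc2c(ccn2-c2ccc(NC(=O)Nc3cccc(Cl)c3Cl)cc2)n1` gives 9800 nM. Compound 3 thus sits at the high end of the three numbers: compound 2 lies within the scatter of it, while compound 1 lies lower, beyond the scatter. Within the data shown here, the one step that has been measured, a 2.7-fold higher number from compound 1 to compound 2 (0.44 log units; beyond the scatter), concerns the carbonyl group on the core and not the ring on the urea.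

Compound 4 `NC(=O)c1ccc2c(ccn2-c2ccc(NC(=O)Nc3ccc(Cl)c(C(F)(F)F)c3)cc2)n1` differs from compound 3 in one place: 4-chloro-3-(trifluoromethyl)phenyl in place of 2,3-dichlorophenyl on an amide-type nitrogen. Among the measured compounds shown here, no measured step changes this ring, so nothing directly tells how large the step in this assay should be. What the numbers do show is that compounds 1 and 2, which both carry the 4-chloro-3-(trifluoromethyl)phenyl group, and compound 3, which carries 2,3-dichlorophenyl, all fall within a modest span, with compound 2 and compound 3 within the scatter of each other. Compound 4 is therefore expected to land close to compound 3, with the expected step of a 1.2-fold lower number from compound 3 to compound 4 (0.09 log units; within the scatter) lying within the scatter. The estimate for compound 4 is 8000 nM, with a range from 3000 nM to 20000 nM.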

Compound 4, half-maximal inhibitory concentration: > 10000 nM
Compound 4 gave a limit, no number; the forecaster's own chance of this, stated with the estimate: 5%; middle value at least 1.2-fold (0.09 log units) away from the limit.
By their numbers in this assay, from the lowest: compound 1; then compounds 2 and 3 (each within the scatter of the next). At a limit, above all of these: compound 4.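

In this assay, the result for compound 4 is a limit and not a number: the limit of > 10000 nM in this assay, at which 1 of the 4 values shown sits. Putting 4-chloro-3-(trifluoromethyl)phenyl in place of 2,3-dichlorophenyl on the amide-type nitrogen gives an at least 1.0-fold higher number from compound 3 to compound 4 (0.00 log units; that floor lies within the scatter), and amino in place of methoxy on the carbonyl carbon gives an at least 1.2-fold higher number from compound 2 to compound 4 (0.08 log units; that floor lies within the scatter), so neither change is shown to move the number in either direction. Among these compounds, the one clear new reading concerns the benzyl group: hydrogen in place of benzyl on the amide-type nitrogen gives an at least 3.3-fold higher number from compound 1 to compound 4 (0.52 log units; beyond the scatter), which points the same way as a 2.7-fold higher number from compound 1 to compound 2 (0.44 log units; beyond the scatter), so both changes that remove the benzylamino group from compound 1 raise the number.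

Going by these compounds, how far compound 4 lies past its limit stays open, and with it the true size of all three new steps. Also open, on these data alone, is whether a methyl group or a longer chain such as phenethyl on that amide nitrogen, or a carboxylic acid in place of the amide, would give a number nearer to that of compound 1 or to those of the other compounds.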